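This account rests on a few compounds, and the source may have more. Where it says the series, first, only, none or still open, it means among the compounds named here.

Compound 2 `COc1nc2ccc(Br)cc2cc1C(c1ccccc1)n1cc(CCO)nn1` gives 4.54% in an ADME assay on HEK293 cells (Homo sapiens) for cytotoxicity, read by sulforhodamine B assay, with a stated time of 48 h, tested at 10 uM (on this read-out higher numbers stand for more inhibition at the one concentration tested (going by the name of the read-out) and lower numbers for less inhibition), while compound 1 `COc1nc2ccc(Br)cc2cc1C(c1ccccc1)n1cc(-c2ccccc2F)nn1` gives 3.97%; the step of a number 0.6 percentage points higher from compound 1 to compound 2 (within the scatter) lies within the scatter, so the two stand together. Compound 3 `COc1nc2ccc(Br)cc2cc1C(c1ccccc1)n1cc(CCCCCO)nn1` differs from compound 2 by 3-hydroxypropyl in place of hydroxy on a saturated chain carbon, two bonds along the chain from an aromatic carbon. Among the measured compounds shown here, no measured step touches this saturated chain; the only step available, from compound 1 to compound 2, exchanged a group on an aromatic carbon and stayed within the scatter. In this assay the expected step is therefore a number 0.5 percentage points higher from compound 2 to compound 3 (within the scatter), none beyond the scatter. Compound 3 is estimated at 5%, between -5% and 20%.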

Compound 3, a percentage reported as inhibition, at one concentration (the size of the read-out at that concentration, not a potency): 7.96%
Compound 3: the middle estimate sits 3 percentage points below what was measured; the range from low to high includes it.
By their numbers in this assay, from the lowest: compounds 1, 2 and 3 (each within the scatter of the next).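

In this assay the step of a number 3.4 percentage points higher from compound 2 to compound 3 (within the scatter) gives this saturated chain carbon its first measured change, and 3-hydroxypropyl in place of hydroxy stays within the scatter. The step of a number 4 percentage points higher from compound 1 to compound 3 (within the scatter) also stays within the scatter, so 5-hydroxypentyl and 2-fluorophenyl on the aromatic carbon stand together. No evidence at hand bears on these results. On these data alone, whether an amine or a carboxylic acid in place of hydroxy on this saturated chain carbon, or a longer chain, would move the number beyond the scatter stays open.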